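Trifluoromethoxy for Fluoro on a Shared Core

This account rests on a few compounds, and the source may have more. Where it says the series, first, only, none or still open, it means among the compounds named here.

compound 1 `Oc1ccccc1-c1cc(-c2cccc(F)c2)cc(-c2ccccc2O)n1` — in a functional assay on HeLa cells (Homo sapiens) for inhibition (on this read-out lower numbers stand for stronger inhibition and higher numbers for weaker inhibition), compound 1 gives > 50000 nM, which is a limit of the assay rather than a number.
compound 2 `Oc1cccc(-c2cc(-c3cccc(F)c3)cc(-c3ccccc3O)n2)c1` — in this assay compound 2 gives > 50000 nM, again a limit of the assay.

Compound 1 stands at the limit of > 50000 nM in this assay, at which 2 of the 2 values shown sit. Going by the values given here, the only measured step, a step that the two limits leave unreadable from compound 1 to compound 2, therefore tells nothing about size or direction. Compound 3 `Oc1ccccc1-c1cc(-c2cccc(OC(F)(F)F)c2)cc(-c2ccccc2O)n1` differs from compound 1 by trifluoromethoxy in place of fluoro on an aromatic carbon. Among the compounds with values here, no measured step bears on this exchange, so no movement in this assay beyond the scatter is expected. Compound 3 is estimated at 50000 nM, with a range from 15000 nM to 200000 nM, most likely reported as a limit once more. The step of a number no higher from compound 1 to compound 3 (the limit leaves the size open) is thus expected to be flat.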

Compound 3, half-maximal inhibitory concentration: > 50000 nM
Compound 3: only a limit was reported (the forecaster's own chance of this, stated with the estimate: 80%); the middle value sits exactly at the limit.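

No size or direction can be read for the exchange from compound 1 to compound 3 in this assay, since both give only a limit: the limit of > 50000 nM in this assay, at which 3 of the 3 values shown sit.

The compounds shown leave open how strongly any of them inhibits and how trifluoromethoxy compares with fluoro on the shared core.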